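A few compounds are considered here, and "the series" means these few. Any claim that something is new, unique, unknown or untested is made for them only; others in the source may bear on it.

Of the compounds shown here, two built on the same core have been measured in an assay on microsomes for inhibition of acyl-CoA:cholesterol acyltransferase (Oryctolagus cuniculus); on this read-out lower numbers stand for stronger inhibition and higher numbers for weaker inhibition. Compound 1 `CC(C)c1cccc(C(C)C)c1NC(=O)NCC1(c2ccc(C(C)(C)C)cc2)CCCC1` gives 63 nM, and compound 2 `CC(C)c1cccc(C(C)C)c1NC(=O)NCC1(c2ccc(Cl)cc2)CCCC1` gives 32 nM. Going by the values given here, the single step between them, a 2.0-fold lower number from compound 1 to compound 2 (0.29 log units; within the scatter), came with chloro in place of tert-butyl on an aromatic carbon, so the two numbers cannot be told apart. Among the numbers seen so far, compound 2 sits within the scatter of compound 1, and neither can be called stronger. Compound 3 `CC(C)c1cccc(C(C)C)c1NC(=O)NCC1(c2ccc(C(=O)O)cc2)CCCC1` has not yet been measured; it differs from compound 2 by carboxy in place of chloro on an aromatic carbon. Among the compounds with values here, no measured step touches a carboxy group entering at this place; the only step on record involved neither group and stayed within the scatter, so there is little to rest on. The step is nonetheless expected to weaken inhibition, a 31-fold higher number from compound 2 to compound 3 (1.49 log units; beyond the scatter). Compound 3 is estimated at 1000 nM, with a range from 150 nM to 8000 nM.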

Compound 3, half-maximal inhibitory concentration: 3100 nM
For compound 3 the middle estimate is 3.1-fold (0.49 log units) below the measured one; the range from low to high includes it.
By their numbers in this assay, from the lowest: compounds 2 and 1 (each within the scatter of the next); then compound 3.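

In this assay this position on the aromatic ring proves far from indifferent to what it carries: there is a 97-fold higher number from compound 2 to compound 3 (1.99 log units; beyond the scatter) with carboxy in place of chloro, and a 49-fold higher number from compound 1 to compound 3 (1.69 log units; beyond the scatter) with carboxy in place of tert-butyl. Going by these compounds alone, the earlier swap of tert-butyl for chloro stayed within the scatter, so this is the first large step seen here, and it arrives with a group that, unlike chloro, brings a hydrogen-bond donor and a hydrogen-bond acceptor. Nothing in the available data explains why inhibition falls so sharply with this change. Going by these compounds, it remains open whether this loss is particular to carboxy or would also follow other groups at this place, such as an amine, a methyl ester or a primary amide. The compounds shown also cannot tell whether a carboxy group elsewhere on the shared core would cost as much.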